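The source may hold more compounds than are shown below. What is called first, only, known or untested is meant among the compounds shown, and "the series" means these compounds.

Measured compounds:

- compound 1, `O=C(Cn1c(=O)oc2ccccc21)Nc1cc(C(F)(F)F)ccc1Cl`, 12.3%
- compound 2, `O=C(Cn1c(=O)oc2cc(Cl)ccc21)Nc1cc(C(F)(F)F)ccc1Cl`, 1.61%
- compound 3, `O=C(Cn1c(=O)oc2ccccc21)Nc1nc2ccc([N+](=O)[O-])cc2s1`, 12.4%

All three values come from an ADME assay on RAW264.7 cells (Mus musculus) for cytotoxicity, read by MTT assay, with a stated time of 72 h, tested at 50 uM; on this read-out lower numbers stand for a weaker effect and higher numbers for a stronger effect at the one concentration tested. Compound 1 gives 12.3% and compound 3 gives 12.4% in this assay; the two lie within the scatter of each other, and the difference between these two cores is not broken down here. Going by the values given here, the one counted step is chloro in place of hydrogen on an aromatic carbon, which gives a number 10.7 percentage points lower from compound 1 to compound 2 (beyond the scatter).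

Compound 4, `O=C(Cn1c(=O)oc2cc(Cl)ccc21)Nc1nc2ccc([N+](=O)[O-])cc2s1`, has not yet been run in this assay. It differs from compound 3 by chloro in place of hydrogen on an aromatic carbon, the same change as from compound 1 to compound 2. Because compound 2 shows a number 10.7 percentage points lower from compound 1 to compound 2 (beyond the scatter), a step of about that size is expected again, a number 9.4 percentage points lower from compound 3 to compound 4 (within the scatter). Compound 4 is therefore estimated at 3%, with a range from -5% to 12%, resting on a single precedent only.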

Compound 4, a percentage reported as inhibition, at one concentration (the size of the read-out at that concentration, not a potency): 12.5%
Estimate against measurement, compound 4: 9.5 percentage points below; measured number above the stated range.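

In this assay, chloro in place of hydrogen on an aromatic carbon gives a number 0.1 percentage points higher from compound 3 to compound 4 (within the scatter). Set beside the earlier step, the two results cannot be told apart: the same change on two cores in this assay, a number 10.7 percentage points lower (beyond the scatter) from compound 1 to compound 2 and a number 0.1 percentage points higher (within the scatter) from compound 3 to compound 4, 10.8 percentage points apart, within the scatter of two such steps. This gives no firm sign that the change acts differently on the two cores, but it does not establish that the step carries over at a shared size, and two steps are too few to fix one.

Still open, going by these compounds, is how another group on the same aromatic carbon, such as fluoro, methoxy or an amine, reads on either core. Also open, on these data alone, is how the chloro step reads at other concentrations.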